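The source may report more compounds than this note shows. Statements on the series, on what has been measured and on what is new or still open speak of the compounds shown alone.

Compound 1 `C[n+]1ccn(COCCCS(C)(=O)=O)c1/C=N/O` and compound 2 `C[n+]1ccn(COCCCCS(C)(=O)=O)c1/C=N/O` share one core and differ by (methylsulfonyl)methyl in place of methylsulfonyl on a saturated chain carbon, three bonds along the chain from an oxygen on a saturated carbon. In a physicochemical assay for lipophilicity (on this read-out lower numbers stand for lower lipophilicity and higher numbers for higher lipophilicity), compound 1 gives -2.5 and compound 2 gives -3.11, a step of a number 0.61 log units lower from compound 1 to compound 2 (beyond the scatter). Compound 3 `C[n+]1ccn(CCCS(C)(=O)=O)c1/C=N/O` is built on another core; how its core differs from that of compound 1 is not broken down here. In this assay compound 3 gives -2.7. Compound 4 `C[n+]1ccn(CCCCS(C)(=O)=O)c1/C=N/O` has not yet been measured and differs from compound 3 by (methylsulfonyl)methyl in place of methylsulfonyl on a saturated chain carbon, three bonds along the chain from an aromatic nitrogen. This is the same kind of change as the earlier one, though at a different place: there the chain carbon lay three bonds along the chain from an oxygen on a saturated carbon, here three bonds along the chain from an aromatic nitrogen. Within the data shown here, compound 4 is expected to show a step of a number 0.60 log units lower from compound 3 to compound 4 (beyond the scatter) in this assay because a number 0.61 log units lower from compound 1 to compound 2 (beyond the scatter) is the one measured instance of this kind of change. Compound 4 is therefore estimated at -3.3, with a range from -3.7 to -2.9.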

Compound 4, distribution coefficient: -3.4
Estimate against measurement, compound 4: 0.10 log units above, and the stated range covers the measured number.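

In this assay, putting (methylsulfonyl)methyl in place of methylsulfonyl gives a number 0.70 log units lower from compound 3 to compound 4 (beyond the scatter), and the same kind of change on the core of compound 1 gives a number 0.61 log units lower from compound 1 to compound 2 (beyond the scatter), so the step runs the same way on both cores and each step is beyond the scatter. Among these compounds, these are only two pairs, so they show that the change carried over between these two cores, not that it would do so on any other core. Nothing measured here explains the result.

The compounds shown leave open what a longer chain ending in methylsulfonyl would give on either core. They also leave open what an amine or a carboxylic acid would give in place of methylsulfonyl on a saturated chain carbon.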